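A few compounds are considered here, and "the series" means these few. Any claim that something is new, unique, unknown or untested is made for them only; others in the source may bear on it.

Working notes on the series. In an ADME assay on Vero cells (Chlorocebus sabaeus) for cytotoxicity (a lower number here means that less compound is tolerated, a higher number that more compound is tolerated), compound 1 (`Oc1ccc(-c2nc3c(NC4CCCC4)cccn3c2-c2ccnc(NC3CCCC3)n2)cc1`) gives > 40000 nM, which is a limit and not a number. In the same assay, compound 2 (`Fc1ccc(-c2nc3c(N4CCCC4)cccn3c2-c2ccnc(NC3CCCC3)n2)cc1`) gives > 40000 nM, which is also a limit and not a number. Compound 2 therefore stands with compound 1 at the limit of > 40000 nM in this assay, at which 2 of the 2 values shown sit.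

Compound 3 (`Fc1ccc(-c2nc3ccccn3c2-c2ccnc(NC3CCCC3)n2)cc1`) differs from compound 2 in one place: hydrogen in place of pyrrolidin-1-yl on an aromatic carbon. Hydrogen replaces pyrrolidin-1-yl on an aromatic carbon of a six-membered aromatic ring with 1 nitrogen, part of a fused or bridged system of two rings.

Going by the values given here, no measured step is available in this assay, so the expectation rests only on these two limits. The estimated a number no higher from compound 2 to compound 3 (the limit leaves the size open) is expected to stay within the scatter, with no direction favoured. For compound 3, the expected value is 40000 nM, with an estimated range of 20000 nM to 60000 nM.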

Compound 3, half-maximal cytotoxic concentration: > 40000 nM
Compound 3 gave a limit, no number (the forecaster's own chance of this, stated with the estimate: 75%); the middle value lies on the limit itself.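

In this assay compound 3 gives > 40000 nM, again a limit and not a number, so no step can be read between compound 2 and compound 3. The compounds shown leave open whether their true values in this assay differ at all, as all share one limit: the limit of > 40000 nM in this assay, at which 3 of the 3 values shown sit.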